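Shortening an Alkyl Amide Chain After an Aryl Hydrazide

A few compounds are considered here, and "the series" means these few. Any claim that something is new, unique, unknown or untested is made for them only; others in the source may bear on it.

Two compounds share one core that carries an amide, a urea and a sulfonyl group; they differ only in the group on an amide-type nitrogen. Compound 1 `CCCCNC(=O)c1c(NC(=O)NS(=O)(=O)c2ccccc2)sc2c1CCCCC2` carries butyl there, and in a functional assay on cells (Cancer cell lines, Homo sapiens) for inhibition, with a stated time of 48 h (on this read-out higher numbers stand for weaker inhibition of growth and lower numbers for stronger inhibition of growth), compound 1 gives 72300 nM. Compound 2 `O=C(Nc1sc2c(c1C(=O)NNc1ccc(Cl)cc1)CCCCC2)NS(=O)(=O)c1ccccc1` carries (4-chlorophenyl)amino instead. In this assay compound 2 reaches only a limit, > 100000 nM, so compound 2 stands at the limit of > 100000 nM in this assay, at which 1 of the 2 values shown sits, rather than at a number. Among the measured compounds shown here, the one measured step, an at least 1.3-fold higher number from compound 1 to compound 2 (0.14 log units; that floor lies within the scatter), thus moves from a number to a limit. Compound 3 `CCCNC(=O)c1c(NC(=O)NS(=O)(=O)c2ccccc2)sc2c1CCCCC2` is still to be measured; its change from compound 2 is propyl in place of (4-chlorophenyl)amino on an amide-type nitrogen. Because a short alkyl chain gave 72300 nM for compound 1, the return to propyl is expected to lower the number, by about an at least 1.2-fold lower number from compound 2 to compound 3 (0.09 log units; that floor lies within the scatter). Compound 3 is therefore estimated at 80000 nM, within 30000 nM to 200000 nM.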

Compound 3, concentration for 50% growth inhibition: 80300 nM
The estimate for compound 3 lay 1.0-fold (0.00 log units) below the measured number; the range from low to high includes it.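

The alkyl chain on this amide-type nitrogen can now be compared at two lengths, butyl and propyl, and in this assay the result is a 1.1-fold higher number from compound 1 to compound 3 (0.05 log units; within the scatter), so these two chain lengths cannot be told apart. Replacing the (4-chlorophenyl)amino group with propyl gives an at least 1.2-fold lower number from compound 2 to compound 3 (0.09 log units; that floor lies within the scatter), so no real separation between the aryl and alkyl groups can be claimed from these values. Compound 2 gives only a limit, not a number, which leaves the true size of this step unknown: the limit of > 100000 nM in this assay, at which 1 of the 3 values shown sits.

As far as these compounds go, it remains open whether a longer chain such as octyl, or a chain ending in an amine or a carboxylic acid, would shift the number beyond the scatter. From the compounds shown here alone, how far compound 2 truly lies from the two alkyl amides also remains open.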